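Replacing Iodo with Thiophen-3-yl on a Methylamino Nucleoside

This account rests on a few compounds, and the source may have more. Where it says the series, first, only, none or still open, it means among the compounds named here.

Measured so far in a functional assay on HL-60 cells (Homo sapiens) for antiproliferative activity, read by XTT assay, with a stated time of 72 h; on this read-out higher numbers stand for weaker inhibition and lower numbers for stronger inhibition:
- compound 1, `COc1ncnc2c1c(-c1ccsc1)cn2[C@@H]1O[C@H](CO)[C@@H](O)[C@H]1O`: 130 nM
- compound 2, `CN(C)c1ncnc2c1c(-c1ccsc1)cn2[C@@H]1O[C@H](CO)[C@@H](O)[C@H]1O`: 1920 nM
- compound 3, `CNc1ncnc2c1c(I)cn2[C@@H]1O[C@H](CO)[C@@H](O)[C@H]1O`: > 20000 nM

Compounds 1 and 2 share the thiophen-3-yl group and differ only at the neighbouring aromatic carbon, where a 15-fold higher number from compound 1 to compound 2 (1.17 log units; beyond the scatter). Compound 3 carries a methylamino group instead and an iodo group where the other two carry thiophen-3-yl. In this assay compound 3 reaches only the limit (the limit of > 20000 nM in this assay, at which 1 of the 3 values shown sits), so no number is known for it, and it stands apart from compounds 1 and 2, which both gave measurable values.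

Compound 4, `CNc1ncnc2c1c(-c1ccsc1)cn2[C@@H]1O[C@H](CO)[C@@H](O)[C@H]1O`, keeps the methylamino group of compound 3 and differs from it in one place: thiophen-3-yl in place of iodo on an aromatic carbon. Going by the values given here, no measured pair differs in exactly this way, so no step on record bears directly on it; the one measured step, from compound 1 to compound 2, concerns the other aromatic carbon. Still, both compounds that carry thiophen-3-yl gave measurable values, so compound 4 is expected to move off the limit, with an at least 66-fold lower number from compound 3 to compound 4 (1.82 log units; beyond the scatter) as the estimated step. The estimate for compound 4 in this assay is 300 nM, expected between 60 nM and 3000 nM.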

Compound 4, half-maximal inhibitory concentration: > 20000 nM
Compound 4 was reported as a limit (the forecaster's own chance of this, stated with the estimate: 10%); middle value at least 66-fold (1.82 log units) from the limit.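

In this assay compound 4 stays at a limit, not a number, just as compound 3 does, so thiophen-3-yl in place of iodo gives no measurable value here and the step between them cannot be read: the limit of > 20000 nM in this assay, at which 2 of the 4 values shown sit.

The group on the carbon that carries methoxy in compound 1 matters far more in this series: with thiophen-3-yl kept, methylamino in place of methoxy gives an at least 150-fold higher number from compound 1 to compound 4 (2.18 log units; beyond the scatter), and hydrogen in place of methyl on the nitrogen gives an at least 10-fold higher number from compound 2 to compound 4 (1.01 log units; beyond the scatter). Among these compounds, then, thiophen-3-yl alone does not secure a measurable value, and both compounds with a methylamino group sit at the limit.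

Going by these compounds, how far compound 4 lies past its limit stays open. So does whether an unsubstituted amino group or an ethylamino group on that carbon would give a measurable value.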